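Two Methyl Groups in Place of Two Chlorines

The source may report more compounds than this note shows. Statements on the series, on what has been measured and on what is new or still open speak of the compounds shown alone.

Of the compounds shown here, two have so far been tested in a functional assay on the whole organism for inhibition, with Mus musculus as the target, in the writhing test, with a stated time of 1 h, at a dose of 10 mg/kg by the oral route; a lower number here means less inhibition, a higher number more inhibition at the dose given (going by the name of the read-out). Compound 1, `COc1ccc(N2CCN(CCC(OC(N)=O)c3ccc(Cl)c(Cl)c3)CC2)cc1`, gives 61%. Compound 2, `NC(=O)OC(CCN1CCN(c2ccccc2O)CC1)c1ccccc1`, gives 37%. Among the compounds with values here, compound 1 therefore stands highest of the two numbers, and the gap to compound 2, its only neighbour, lies beyond the usual scatter of repeated measurements. Within the data shown here, these two compounds differ in more than one place, so no single structural step between them can be picked out; their two values show only that one is clearly higher than the other.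

Compound 3, `COc1ccc(N2CCN(CCC(OC(N)=O)c3ccc(C)c(C)c3)CC2)cc1`, has not yet been measured. It differs from compound 1 in one place: 3,4-dimethylphenyl in place of 3,4-dichlorophenyl on a saturated chain carbon bound to an oxygen next to a carbonyl group and a saturated chain carbon. The shared core of compound 1 is otherwise kept. Among the measured compounds shown here, no measured pair shows what this kind of exchange does here, so there is no measured step to lean on, and the expectation rests on the structural change alone. In this assay compound 3 is expected to give about 50%, most likely between 25% and 75%. This corresponds to an expected step of a number 11 percentage points lower from compound 1 to compound 3 (beyond the scatter), a small fall that may well stay within the scatter.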

Compound 3, a percentage reported as inhibition, in the whole organism at one dose (the size of the read-out at that dose, not a potency): 58%
Compound 3: middle estimate off by 8 percentage points, on the low side; measured number inside the range.
By their numbers in this assay, from the lowest: compound 2; then compounds 3 and 1 (each within the scatter of the next).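

Within the data shown here, putting 3,4-dimethylphenyl in place of 3,4-dichlorophenyl on a saturated chain carbon bound to an oxygen next to a carbonyl group and a saturated chain carbon gives, in this assay, a number 3 percentage points lower from compound 1 to compound 3 (within the scatter) as the first step in this set that can be read at a single place. At this one dose, the read-out does not separate the two groups, so a compound carrying chlorine at this place and one carrying only carbon and hydrogen in the same group cannot be told apart, although the two groups differ in their atoms while matching in heavy-atom count. Nothing measured on these groups beyond this read-out is at hand to explain the result.

The compounds shown leave open what happens at this place with a group that departs further from these two, such as an aryl group carrying an amine or a carboxylic acid. They also leave open whether compound 1 and compound 3 would stay this close at other doses, since a single-dose percentage is a size of effect and not a potency.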